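Fluoro in Place of Hydrogen on the Anilino Ring of Compound 1

The source may report more compounds than this note shows. Statements on the series, on what has been measured and on what is new or still open speak of the compounds shown alone.

Compound 1 `C=C1[C@@H](OC(C)=O)C[C@@H]2[C@](C)(CO[Si](C)(C)C(C)(C)C)[C@H](OC(C)=O)CC[C@@]2(C)[C@@H]1C[C@@H](Nc1ccccc1)C1=CCOC1=O` carries a silyl ether and an unsubstituted anilino group. In a functional assay on KB cells (Homo sapiens) for cytotoxicity, read by sulforhodamine B assay (on this read-out higher numbers stand for weaker inhibition and lower numbers for stronger inhibition), compound 1 gives 5710 nM, the lowest of the three numbers measured. Compound 3 `C=C1[C@@H](OC(C)=O)C[C@@H]2[C@](C)(COC=O)[C@H](OC(C)=O)CC[C@@]2(C)[C@@H]1C[C@@H](Nc1ccccc1)C1=CCOC1=O`, which replaces the silyl ether by a formate on an oxygen on a saturated carbon, gives 32100 nM; the step is a 5.6-fold higher number from compound 1 to compound 3 (0.75 log units; beyond the scatter). Compound 2 `C=C1[C@@H](OC(C)=O)C[C@@H]2[C@](C)(COC=O)[C@H](OC(C)=O)CC[C@@]2(C)[C@@H]1C[C@@H](Nc1ccccc1C(=O)O)C1=CCOC1=O` adds a carboxy group to the anilino ring of compound 3; in this assay compound 2 gives 42500 nM, and the step of a 1.3-fold lower number from compound 2 to compound 3 (0.12 log units; within the scatter) stays within the scatter.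

Compound 4 `C=C1[C@@H](OC(C)=O)C[C@@H]2[C@](C)(CO[Si](C)(C)C(C)(C)C)[C@H](OC(C)=O)CC[C@@]2(C)[C@@H]1C[C@@H](Nc1ccc(F)cc1)C1=CCOC1=O` differs from compound 1 by fluoro in place of hydrogen on an aromatic carbon. Going by the values given here, no measured step alters the anilino ring within the silyl ether series. Among the compounds with values here, the only change on that ring among the measured compounds, a 1.3-fold lower number from compound 2 to compound 3 (0.12 log units; within the scatter), concerns a different group and lies within the scatter, and it involves the formate series rather than compound 1. Nothing measured therefore points to a shift of any size, and the expected step for compound 4 is a 1.0-fold lower number from compound 1 to compound 4 (0.02 log units; within the scatter), none beyond the scatter. Compound 4 is accordingly estimated at 5500 nM, with a range from 2000 nM to 15000 nM reflecting the absence of a direct precedent.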

Compound 4, half-maximal inhibitory concentration: 5090 nM
Beside the measured number, compound 4's estimate is 1.1-fold (0.03 log units) above it; the measured number falls inside the stated range.
By their numbers in this assay, from the lowest: compounds 4 and 1 (each within the scatter of the next); then compounds 3 and 2 (each within the scatter of the next).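

Fluoro in place of hydrogen, on an aromatic carbon para to a large group, is the only change shown on the anilino ring of the silyl ether series, and in this assay it reads as a 1.1-fold lower number from compound 1 to compound 4 (0.05 log units; within the scatter). At this position, then, the fluoro leaves the number of compound 1 within the scatter, a result that the earlier ring change, a 1.3-fold lower number from compound 2 to compound 3 (0.12 log units; within the scatter), could not show, since that step concerns carboxy in the formate series. Among the single-place steps, only the change on the oxygen, a 5.6-fold higher number from compound 1 to compound 3 (0.75 log units; beyond the scatter), lies beyond the scatter, and nothing in the data accounts for the fluoro step.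

It remains open whether a methoxy group, an amine or a carboxylic acid in the place of the fluoro would read the same in the silyl ether series, where fluoro is the only ring substituent shown. The compounds shown also leave open whether the 4-fluorophenyl group would give a similar step when carried on the formate of compound 3.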